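This account rests on a few compounds, and the source may have more. Where it says the series, first, only, none or still open, it means among the compounds named here.

In an ADME assay on BHK-21 cells (Mesocricetus auratus) for cytotoxicity, read by MTT assay, with a stated time of 72 h (on this read-out higher numbers stand for lower toxicity in this test and lower numbers for higher toxicity in this test), three compounds that share a core have been measured. Compound 1 `Cc1cccc(C2CC(c3ccc(Oc4ccccc4)cc3)=NN2c2ccc(S(N)(=O)=O)cc2)c1` gives 8000 nM and compound 3 `Cc1cccc(C2CC(c3ccc(OCc4ccccc4)cc3)=NN2c2ccc(S(N)(=O)=O)cc2)c1` gives 8000 nM, which leaves the two level and together the lowest of the three numbers, while compound 2 `Cc1cccc(C2CC(c3ccccc3)=NN2c2ccc(S(N)(=O)=O)cc2)c1` gives 25000 nM. Compound 4 `NS(=O)(=O)c1ccc(N2N=C(c3ccc(Oc4ccccc4)cc3)CC2c2cccc(Cl)c2)cc1` keeps the core of compound 1 and its phenoxy group but carries chloro in place of methyl on an aromatic carbon, meta to a large group, so that 3-methylphenyl becomes 3-chlorophenyl (chloro in place of methyl on an aromatic carbon).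

The measured steps offer only indirect guidance. Hydrogen in place of phenoxy gave a 3.1-fold higher number from compound 1 to compound 2 (0.49 log units; beyond the scatter), benzyloxy in place of hydrogen gave a 3.1-fold lower number from compound 2 to compound 3 (0.49 log units; beyond the scatter), and benzyl in place of phenyl on the oxygen gave no change at the digits printed from compound 1 to compound 3 (within the scatter). Among the measured compounds shown here, all three concern the phenoxy side, and none of them changes the methyl group, so no measurement yet tests the exchange made in compound 4. With nothing to indicate a direction, no shift beyond the scatter is expected in this assay, and the estimated change is a 1.1-fold lower number from compound 1 to compound 4 (0.06 log units; within the scatter). For compound 4 the expected value is 7000 nM, with an estimated range from 3500 nM to 14000 nM.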

Compound 4, half-maximal cytotoxic concentration: 9000 nM
The estimate for compound 4 lay 1.3-fold (0.11 log units) below the measured number; low and high end bracket the measured number.
By their numbers in this assay, from the lowest: compounds 1, 3 and 4 (each within the scatter of the next); then compound 2.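

In this assay, among the compounds shown here, compound 4 gives the first reading of a change on the 3-methylphenyl side of the series, and chloro in place of methyl gives a 1.1-fold higher number from compound 1 to compound 4 (0.05 log units; within the scatter). With the phenoxy group kept, this exchange on an aromatic carbon, meta to a large group, therefore leaves the number within the scatter, whereas the earlier steps had shown a shift beyond the scatter only on the phenoxy side, as with hydrogen in place of phenoxy, a 3.1-fold higher number from compound 1 to compound 2 (0.49 log units; beyond the scatter). No measurement of any property of the methyl or chloro group is available to account for this result.

The compounds shown test this position with only methyl and chloro, and only with phenoxy on the far side of the core, so it remains open whether the same exchange would also stay within the scatter alongside the benzyloxy group of compound 3 or the hydrogen of compound 2. They also leave open how this read-out would respond to an amine, a carboxylic acid or a longer chain in place of the chloro group.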